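Aryl swap on the ring nitrogen: compound 3 to compound 4

The compounds below may be only part of what the source reports. "The series", "measured", "known", "first", "only" and "open" are said of these compounds alone.

Three analogues on one shared core have numbers in a functional assay on PC-3 cells (Homo sapiens) for inhibition, read by MTT assay, with a stated time of 72 h; a lower number here means a stronger inhibitor, a higher number a weaker inhibitor. Compound 1 `O=C(CSc1nc(Nc2ccccc2)c2ccccc2n1)Nc1ccc(C(F)(F)F)cc1` gives 10400 nM. Going by the values given here, compound 2 `O=C(CSc1nc(Nc2ccccc2)c2ccccc2n1)Nc1ccc(Cl)c(Cl)c1` gives 12100 nM; the step of a 1.2-fold higher number from compound 1 to compound 2 (0.07 log units; within the scatter) is the only single-point change measured so far. Among the compounds with values here, compound 3 `C=CC(=O)Nc1cccc(NC(=O)CSc2nc(Nc3ccccc3C)c3ccccc3n2)c1` gives 23200 nM, the highest of the three numbers; it sits within the scatter of compound 2 and beyond the scatter of compound 1, but it differs from each of them at two places, so no single step to it can be read.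

Compound 4 `C=CC(=O)Nc1cccc(NC(=O)CSc2nc(Nc3ccc(CC)cc3)c3ccccc3n2)c1` is not yet measured. Against compound 3 the change is 4-ethylphenyl in place of 2-methylphenyl on a nitrogen on an aromatic ring. Within the data shown here, no measured step touches the group on the nitrogen on the aromatic ring: the one measured step, a 1.2-fold higher number from compound 1 to compound 2 (0.07 log units; within the scatter), concerns the amide-type nitrogen and stayed within the scatter, and compounds 1 and 2 carry a plain phenyl on that nitrogen while compound 3 carries 2-methylphenyl, with the amide side changed at the same time. Among the measured compounds shown here, the only guide is that the three numbers of this set lie close together, so a step of no more than the scatter is expected in this assay, with no fixed direction. Compound 4 is therefore expected at 20000 nM, within 8000 nM to 50000 nM, which means an expected step of a 1.2-fold lower number from compound 3 to compound 4 (0.06 log units; within the scatter).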

Compound 4, half-maximal inhibitory concentration: 24300 nM
Compound 4: the middle estimate sits 1.2-fold (0.08 log units) below what was measured; low and high end bracket the measured number.
By their numbers in this assay, from the lowest: compounds 1, 2, 3 and 4 (each within the scatter of the next, the first and the last beyond it).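

Going by these compounds alone, replacing 2-methylphenyl with 4-ethylphenyl on a nitrogen on an aromatic ring gives the first readable step at this position in this assay: a 1.0-fold higher number from compound 3 to compound 4 (0.02 log units; within the scatter). The earlier compounds shown here offered only a step on the amide-type nitrogen, so this pair adds that, with the rest of compound 3 held constant, these two aryl groups do not separate at this nitrogen, although they differ in the group carried on the phenyl ring and in where it sits. No supporting data bear on this result, and the pair alone gives no explanation for it.

The steps from compound 1 or compound 2 to compound 3 or compound 4 cannot be read, as each of those pairs differs in two places, so the plain phenyl on this nitrogen cannot be compared with either substituted aryl group. Also open, as far as these compounds go, is whether a phenyl carrying an amine or a carboxylic acid, or a longer chain such as hexyl in place of the ethyl, would move the number at this nitrogen beyond the scatter.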